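This account rests on a few compounds, and the source may have more. Where it says the series, first, only, none or still open, it means among the compounds named here.

Measured compounds in a functional assay (plasma) for inhibition, with Oryctolagus cuniculus as the target; on this read-out higher numbers stand for weaker inhibition and lower numbers for stronger inhibition:
Compound 1, `CC1(C)[C@H]2C[C@H](NC(=O)[C@H](O)C3CCCC3)[C@@H](C/C=C\CCCC(=O)O)[C@@H]1C2`: > 800000 nM, a limit of the assay rather than a number.
Compound 2, `CCCCCc1ccc(S(=O)(=O)N[C@H]2C3CC[C@H](C3)[C@@H]2C/C=C\CCCC(=O)O)cc1`: 800000 nM.
Compound 3, `COc1ccc(S(=O)(=O)N[C@H]2C3CC[C@H](C3)[C@@H]2C/C=C\CCCC(=O)O)cc1`: 1700 nM.

Among the compounds with values here, compound 3 gives the lowest of the two numbers; its nearest neighbour is compound 2, and the gap between them is the single measured step, a 470-fold lower number from compound 2 to compound 3 (2.67 log units; beyond the scatter), a large one arising from methoxy in place of pentyl on an aromatic carbon. Compound 1 sits at the limit of > 800000 nM in this assay, at which 1 of the 3 values shown sits, so it contributes no number to compare.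

Compound 4, `CS(=O)(=O)N[C@H]1C2CC[C@H](C2)[C@@H]1C/C=C\CCCC(=O)O`, is not yet measured. Its change from compound 3 is methyl in place of 4-methoxyphenyl on a sulfonyl sulfur. Within the data shown here, no measured step removes the 4-methoxyphenyl itself; the only step touches the substituent on that ring. That step, a 470-fold lower number from compound 2 to compound 3 (2.67 log units; beyond the scatter), shows the group on the sulfonyl sulfur governs the read-out strongly, so a step beyond the scatter is expected, in the direction of a higher number. Compound 4 is expected to give about 60000 nM in this assay, within 6000 nM to 600000 nM. The expected step is a 35-fold higher number from compound 3 to compound 4 (1.55 log units; beyond the scatter).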

Compound 4, half-maximal inhibitory concentration: 640000 nM
Compound 4: middle estimate off by 11-fold (1.03 log units), on the low side; the whole stated range lies below it.
By their numbers in this assay, from the lowest: compound 3; then compounds 4 and 2 (each within the scatter of the next).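

In this assay, methyl in place of 4-methoxyphenyl on a sulfonyl sulfur gives a 380-fold higher number from compound 3 to compound 4 (2.58 log units; beyond the scatter); this step removes the ring itself, whereas the earlier step changed only the substituent on it. Compound 4 at 640000 nM and compound 2 at 800000 nM lie within the scatter of each other, so the aromatic ring alone does not secure the low number of compound 3: with pentyl on the ring, the value is not distinguishable from that with methyl and no ring. Nothing measured here accounts for the size of either step.

Going by these compounds, whether an unsubstituted phenyl, or hydroxyl, ethoxy or fluorine in place of methoxy, keeps the low number remains open. So does the outcome with a benzyl group or a longer alkyl chain on the sulfonyl sulfur.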